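A few compounds are considered here, and "the series" means these few. Any claim that something is new, unique, unknown or untested is made for them only; others in the source may bear on it.

In a physicochemical assay for solubility, with a stated time of 3 days, at pH 2 (a higher number here means a more soluble compound, a lower number a less soluble compound), compound 1 `CN1CCC(Oc2ccc(-c3nc4cc(C(N)=O)ccc4[nH]3)cc2)C1` stands at "not determined" (no result reported), so it offers no number to start from. Compound 3 `NC(=O)c1ccc2[nH]c(-c3ccc(OC4CCNCC4)cc3)nc2c1` is in the same position, at "not determined" (no result reported). Compound 2 `NC(=O)c1ccc2[nH]c(-c3ccc(OC4CCCNC4)cc3)nc2c1` shares the core and gives > 400000 nM, which is a limit of the assay and not a number. That makes it the only reading available among these three compounds.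

The compound to follow next is compound 4 `CN1CCC(Oc2ccc(-c3nc4cc(C(N)=O)ccc4[nH]3)cc2)CC1`. It carries 1-methylpiperidin-4-yl in place of 1-methylpyrrolidin-3-yl on an oxygen on an aromatic ring, a difference that can be counted as 1-methylpiperidin-4-yl in place of 1-methylpyrrolidin-3-yl on an oxygen on an aromatic ring. Among the measured compounds shown here, no measured pair shows what this change does in this assay, so no step beyond the usual scatter is expected, in either direction. This expectation leans on compound 2 and its limit of > 400000 nM. Compound 4 is estimated at 400000 nM, with an expected range of 200000 nM to 800000 nM, and it may well be reported only as a limit.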

Compound 4, solubility: > 400000 nM
Compound 4: only a limit was reported (the forecaster's own chance of this, stated with the estimate: 70%); the middle value sits exactly at the limit.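

Compound 2 and compound 4 both stop at a limit of the assay and not at a number, so no step between them can be read: the limit of > 400000 nM in this assay, at which 2 of the 4 values shown sit.

The compounds shown leave open how far the solubility of compound 2 and compound 4 differs, and whether 1-methylpiperidin-4-yl in place of 1-methylpyrrolidin-3-yl changes it at all.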